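The source may report more compounds than this note shows. Statements on the series, on what has been measured and on what is new or still open speak of the compounds shown alone.

In an ADME assay on THP-1 cells (Homo sapiens) for inhibition, read by MTT assay, with a stated time of 48 h (a higher number here means a weaker inhibitor, a lower number a stronger inhibitor), the three measured compounds all reached only the limit of the measurement, none giving a number. Compound 1 `O=C(OC[C@H]1O[C@@H](n2cc(COc3ccc4c(-c5ccccc5)cc(=O)oc4c3)nn2)[C@H](OC(=O)c2ccccc2)[C@@H]1OC(=O)c1ccccc1)c1ccccc1` gave > 196000 nM, a limit rather than a value. Compound 2 `O=c1cc(-c2ccccc2)c2ccc(OCc3cn([C@@H]4O[C@H](CO)[C@@H](O)[C@H]4O)nn3)cc2o1` likewise stopped at the limit > 332000 nM. Compound 3 `Cc1cc(=O)oc2cc(-c3cn([C@@H]4O[C@H](CO)[C@@H](O)[C@H]4O)nn3)ccc12` stands at the limit > 417000 nM, and so, as the limit of > 417000 nM in this assay, at which 1 of the 3 values shown sits, records, compound 3 is the one that sits at this particular ceiling; its position relative to compound 1 and compound 2 cannot be ranked, since each of those is also only a limit.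

Compound 4 `O=c1cc(-c2ccccc2)c2ccc(-c3cn([C@@H]4O[C@H](CO)[C@@H](O)[C@H]4O)nn3)cc2o1` differs from compound 3 by a single exchange: phenyl in place of methyl on an aromatic carbon. No measured step between two of the shown compounds exists, so the size of this change cannot be read from a precedent. Given that compound 3 shows only the limit > 417000 nM, compound 4 is expected to remain at or beyond the same region of this assay, with a step of an at least 1.0-fold lower number from compound 3 to compound 4 (0.01 log units; that floor lies within the scatter) that is expected to be no more than the scatter. Compound 4 is therefore estimated at 400000 nM, within a range of 100000 nM to 1500000 nM.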

Compound 4, half-maximal inhibitory concentration: > 355000 nM
Compound 4 ended at the assay's limit (the forecaster's own chance of this, stated with the estimate: 80%); the middle value is on the limit's open side.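

Compound 3 and compound 4 both stand at limits in this assay, and the step between them, phenyl in place of methyl, cannot be read. The compounds shown leave open whether this exchange changes inhibition at all, and what value any of them would reach.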